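The compounds below may be only part of what the source reports. "The series", "measured", "known", "first", "only" and "open" are said of these compounds alone.

Compound 1 `O=C(O)c1ccccc1-n1nc(C(F)(F)F)cc1C(=O)Nc1ccc(S(=O)(=O)N2CCCC2)cc1`: "not determined" (no result reported)
Compound 2 `Cn1nc(C(F)(F)F)cc1C(=O)Nc1ccc(S(=O)(=O)N2CCCCCC2)cc1`: > 300000 nM

In an ADME assay on Vero cells (Chlorocebus sabaeus) for cytotoxicity, read by MTT assay (a lower number here means that less compound is tolerated, a higher number that more compound is tolerated), compound 2 gives > 300000 nM, which is a limit of the assay and not a number. Compound 3 `Cn1nc(C(F)(F)F)cc1C(=O)Nc1ccc(S(=O)(=O)N2CCC[C@H]2C(=O)O)cc1` differs from compound 2 in one place: 2-carboxypyrrolidin-1-yl in place of azepan-1-yl on a sulfonyl sulfur, with 2-carboxypyrrolidin-1-yl in place of azepan-1-yl on a sulfonyl sulfur. Within the data shown here, no measured pair shows the size of such a change in this assay. No step beyond the usual scatter is expected, and this expectation rests on compound 2 alone, with the limit of > 300000 nM in this assay, at which 1 of the 2 values shown sits. The estimated change is a step that the limit leaves unreadable from compound 2 to compound 3. For compound 3 the expected half-maximal cytotoxic concentration is 350000 nM, with an estimated range of 120000 nM to 1000000 nM.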

Compound 3, half-maximal cytotoxic concentration: > 300000 nM
Compound 3 gave a limit, no number (the forecaster's own chance of this, stated with the estimate: 80%); the middle value lies beyond the limit too.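

No step can be read from compound 2 to compound 3: in this assay both results are limits of the assay, not numbers. The compounds shown leave open how far 2-carboxypyrrolidin-1-yl in place of azepan-1-yl shifts the half-maximal cytotoxic concentration, if at all.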